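From trimethoxyphenyl to dihydroxyphenyl: a cytotoxicity step awaited

The source may hold more compounds than are shown below. What is called first, only, known or untested is meant among the compounds shown, and "the series" means these compounds.

Measured so far in a functional assay on HepG2 cells (Homo sapiens) for cytotoxicity, read by MTT assay, with a stated time of 72 h; on this read-out lower numbers stand for stronger inhibition and higher numbers for weaker inhibition:
- Compound 1 `COc1cc2ncnc(Nc3ccc(F)c(Cl)c3)c2cc1NC(=O)N/N=C/c1ccc(F)cc1Cl` gives 29200 nM
- Compound 2 `COc1cc2ncnc(Nc3ccc(F)c(Cl)c3)c2cc1NC(=O)N/N=C/c1ccc(OC)c(OC)c1OC` gives 31200 nM

On these two numbers, compound 2 stands level with compound 1, and the gap between them lies within the scatter. Compound 3 `COc1cc2ncnc(Nc3ccc(F)c(Cl)c3)c2cc1NC(=O)N/N=C/c1ccc(O)cc1O` has yet to be measured. It differs from compound 2 as follows: 2,4-dihydroxyphenyl in place of 2,3,4-trimethoxyphenyl on a carbon with a double bond to nitrogen. In words, it has 2,4-dihydroxyphenyl in place of 2,3,4-trimethoxyphenyl on a carbon with a double bond to nitrogen.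

Among the compounds with values here, one measured step bears on this change, since it exchanges the group at that same place: a 1.1-fold higher number from compound 1 to compound 2 (0.03 log units; within the scatter). That step stays within the scatter, so the two groups compared there give values that cannot be told apart. Within the data shown here, no measured compound carries a 2,4-dihydroxyphenyl group, which leaves the expectation uncertain. In this assay no step beyond the scatter is expected, and the estimated step is a 1.3-fold lower number from compound 2 to compound 3 (0.11 log units; within the scatter) in size. The expected value for compound 3 is 24000 nM with an estimated range from 9000 nM to 60000 nM at this stage.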

Compound 3, half-maximal inhibitory concentration: 32100 nM
For compound 3 the middle estimate is 1.3-fold (0.13 log units) below the measured one; the measured number falls inside the stated range.
By their numbers in this assay, from the lowest: compounds 1, 2 and 3 (each within the scatter of the next).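

In this assay, within the data shown here, the step of a 1.0-fold higher number from compound 2 to compound 3 (0.01 log units; within the scatter) shows that this place, on a carbon with a double bond to nitrogen, tolerates a larger exchange than the earlier compounds covered: 2,3,4-trimethoxyphenyl, with 12 heavy atoms and 0 hydrogen-bond donors, gives way to 2,4-dihydroxyphenyl, with 8 heavy atoms and 2 hydrogen-bond donors, and the two values cannot be told apart. The comparison with the halogen-bearing group reads the same way (a 1.1-fold higher number from compound 1 to compound 3 (0.04 log units; within the scatter)), so 2-chloro-4-fluorophenyl, 2,3,4-trimethoxyphenyl and 2,4-dihydroxyphenyl are all indistinguishable at this place in this read-out. No measurement is at hand that would explain this insensitivity.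

All three groups are substituted phenyl groups, so the compounds shown leave open whether something other than a phenyl group at this place, such as a longer alkyl chain, a carboxylic acid or an amine, would also give a value level with theirs. As far as these compounds go, it also remains open whether a dimethylamino group on the phenyl group would read any differently in this assay.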